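Removal of one aromatic methyl from the 2-methoxyethoxy analogue

This account rests on a few compounds, and the source may have more. Where it says the series, first, only, none or still open, it means among the compounds named here.

Compound 1 `CCOc1cc(C)c(-c2cccc(CNc3ccc(OCC(=O)O)c(F)c3)c2)c(C)c1` gives 24.2 nM in a functional assay on CHO cells for agonist activity at Free fatty acid receptor 1 (Homo sapiens), read by FLIPR and calcium flux; a lower number here means that less compound is needed, a higher number that more compound is needed for the effect. Compound 2 `COCCOc1cc(C)c(-c2cccc(CNc3ccc(OCC(=O)O)c(F)c3)c2)c(C)c1` gives 51.6 nM, and compound 3 `Cc1cc(OCCCS(C)(=O)=O)cc(C)c1-c1cccc(CNc2ccc(OCC(=O)O)c(F)c2)c1` gives 59.8 nM. Compound 2 stands second highest of the three numbers, with compound 3 nearest: a 1.2-fold higher number from compound 2 to compound 3 (0.06 log units; within the scatter), whereas a 2.1-fold higher number from compound 1 to compound 2 (0.33 log units; beyond the scatter) and a 2.5-fold higher number from compound 1 to compound 3 (0.39 log units; beyond the scatter). Compound 4 `COCCOc1ccc(-c2cccc(CNc3ccc(OCC(=O)O)c(F)c3)c2)c(C)c1` differs from compound 2 by hydrogen in place of methyl on an aromatic carbon. Within the data shown here, none of the measured steps bears on this change; all three concern the chain on the aromatic oxygen, not the ring substitution. The expectation therefore rests on compound 2 alone, with wide uncertainty, and the step of a 1.9-fold higher number from compound 2 to compound 4 (0.29 log units; within the scatter) is estimated as modest. Compound 4 is expected to give about 100 nM, within a range of 30 nM to 350 nM.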

Compound 4, half-maximal effective concentration: 41.9 nM
Compound 4: the middle estimate sits 2.4-fold (0.38 log units) above what was measured; the range from low to high includes it.
By their numbers in this assay, from the lowest: compounds 1, 4, 2 and 3 (each within the scatter of the next, the first and the last beyond it).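

Hydrogen in place of methyl on this aromatic carbon, ortho to a large group, gives a 1.2-fold lower number from compound 2 to compound 4 (0.09 log units; within the scatter) in this assay. Among these compounds, with the 2-methoxyethoxy group in place, this methyl can therefore be removed without a change in the read-out beyond the scatter, which the chain steps among the earlier compounds could not show. No measurement available here accounts for this result.

Going by these compounds, whether the same holds with the chains of compound 1 and compound 3 stays open. Also open, on these data alone, is how chlorine, methoxy or trifluoromethyl would behave on this carbon.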